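Small steps on the amide nitrogen so far

This account rests on a few compounds, and the source may have more. Where it says the series, first, only, none or still open, it means among the compounds named here.

Measured in a functional assay on BXPC-3 cells (Homo sapiens) for antiproliferative activity, read by MTT assay, with a stated time of 24 h (a higher number here means a weaker inhibitor, a lower number a stronger inhibitor), so far:
compound 1 `CCn1c(C(=O)NCC(=O)OC)ccc1C(CC)(CC)c1ccc(OCS(=O)(=O)c2ccccc2)c(C)c1` gives 20000 nM
compound 2 `CCn1c(C(=O)N[C@@H](CO)C(C)C)ccc1C(CC)(CC)c1ccc(OCS(=O)(=O)c2ccccc2)c(C)c1` gives 13200 nM
compound 3 `CCn1c(C(=O)N[C@@H](CO)CCCO)ccc1C(CC)(CC)c1ccc(OCS(=O)(=O)c2ccccc2)c(C)c1` gives 16400 nM

Compound 3 cannot be separated from either other compound, with a 1.2-fold lower number from compound 1 to compound 3 (0.09 log units; within the scatter) and a 1.2-fold higher number from compound 2 to compound 3 (0.09 log units; within the scatter) both inside the scatter. The change to compound 4 `CCn1c(C(=O)NC2(C(=O)O)CC2)ccc1C(CC)(CC)c1ccc(OCS(=O)(=O)c2ccccc2)c(C)c1` is a group of 6 heavy atoms (4 carbon, 2 oxygen; one three-membered non-aromatic ring of carbon only) in place of a group of 7 heavy atoms (5 carbon, 2 oxygen; no ring), on an amide-type nitrogen and the rest of the structure stays the same. Among the compounds with values here, the only evidence comes from the swaps on that nitrogen, and even the largest, a 1.5-fold lower number from compound 1 to compound 2 (0.18 log units; within the scatter) in size, stays within the scatter. Within the data shown here, none of the measured compounds carries a 1-carboxycyclopropyl group, so this evidence is indirect. The expected change is a 1.1-fold higher number from compound 3 to compound 4 (0.04 log units; within the scatter) and no step beyond the scatter is expected. For compound 4 the estimated value is 18000 nM in this assay with an expected range of 9000 nM to 35000 nM as its limits.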

Compound 4, half-maximal inhibitory concentration: > 50000 nM
Compound 4: no number, only a limit; the forecaster's own chance of this, stated with the estimate: 15%; middle value at least 2.7-fold (0.44 log units) away from the limit.
By their numbers in this assay, from the lowest: compounds 2, 3 and 1 (each within the scatter of the next). At a limit, above all of these: compound 4.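

In this assay, within the data shown here, the swaps on the amide-type nitrogen had all stayed within the scatter, but 1-carboxycyclopropyl gives the first steps beyond it: an at least 3.0-fold higher number from compound 3 to compound 4 (0.48 log units; beyond the scatter) and an at least 3.7-fold higher number from compound 2 to compound 4 (0.57 log units; beyond the scatter) and also an at least 2.5-fold higher number from compound 1 to compound 4 (0.39 log units; beyond the scatter) in the same direction. This position therefore does respond to the group it carries. Compound 4 has no number, only a limit of the assay: the limit of > 50000 nM in this assay, at which 1 of the 4 values shown sits.

From the compounds shown here alone, the full size of these steps stays open. So does whether carboxymethyl, a carboxylic acid without the ring, or 1-(methoxycarbonyl)cyclopropyl, the ring with an ester, would give the same step.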